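The source may hold more compounds than are shown below. What is called first, only, known or untested is meant among the compounds shown, and "the series" means these compounds.

Among the compounds with values here, compound 1 `Cc1ccc(OCc2nnc(C(=O)Nc3ccc(CCC(=O)O)cc3)s2)c(C)c1` gives 2540 nM in a functional assay on CHO cells for agonist activity at Free fatty acid receptor 1 (Homo sapiens), read by FLIPR and calcium flux, tested at 1 uM (on this read-out higher numbers stand for an effect only at larger amounts of compound and lower numbers for an effect already at smaller amounts), the second highest of the three numbers measured so far; its nearest neighbour is compound 2 `COc1ccc(OCc2nnc(C(=O)Nc3ccc(CCC(=O)O)cc3)s2)cc1`, with 2430 nM, and the furthest is compound 3 `O=C(O)CCc1ccc(NC(=O)c2nnc(Cc3cccc(F)c3)s2)cc1`, with 5020 nM. The step of a 1.0-fold lower number from compound 1 to compound 2 (0.02 log units; within the scatter) shows that swapping one aryl on the ether oxygen for another leaves the number unchanged. Replacing the whole aryloxy group with an aryl bound directly to the saturated carbon costs a little: a 2.0-fold higher number from compound 1 to compound 3 (0.30 log units; within the scatter), and from the methoxy analogue a 2.1-fold higher number from compound 2 to compound 3 (0.32 log units; beyond the scatter).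

Compound 4 `O=C(O)CCc1ccc(NC(=O)c2nnc(Cc3ccc(Cl)cc3)s2)cc1` makes the same kind of change from compound 1: 4-chlorophenyl in place of 2,4-dimethylphenoxy on a saturated chain carbon bound to an aromatic carbon. The two steps above are the relevant precedents; both point to a modestly higher number, around the edge of the scatter. A similar outcome is therefore expected for compound 4, estimated at a 1.8-fold higher number from compound 1 to compound 4 (0.25 log units; within the scatter). Compound 4 is expected to give 4500 nM in this assay, within a range of 2000 nM to 10000 nM; the chlorine rather than fluorine, and its differing ring position, add uncertainty to this estimate.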

Compound 4, half-maximal effective concentration: 2390 nM
Compound 4: the middle estimate sits 1.9-fold (0.27 log units) above what was measured; measured number inside the range.
By their numbers in this assay, from the lowest: compounds 4, 2, 1 and 3 (each within the scatter of the next, the first and the last beyond it).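

In this assay, the steps of a 1.1-fold lower number from compound 1 to compound 4 (0.03 log units; within the scatter) and a 1.0-fold lower number from compound 2 to compound 4 (0.01 log units; within the scatter) show that an aryl bound directly to the saturated chain carbon need not cost anything against either aryloxy group. The modest rise seen with compound 3 therefore does not follow from losing the aryloxy group as such, and compound 3 goes against any match between directly bound aryls and aryloxy groups, as the step of a 2.1-fold lower number from compound 3 to compound 4 (0.32 log units; beyond the scatter) shows a difference between 3-fluorophenyl and 4-chlorophenyl. No measurement here gives a reason for this difference.

The halogen and its place on the ring change together between compound 3 and compound 4, so 3-chlorophenyl and 4-fluorophenyl on the same carbon would be needed to separate the two. As far as these compounds go, whether a longer chain between the core and the 4-chlorophenyl ring is tolerated also remains open.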